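Trimming the Piperidine Amine: Compound 3 to Compound 4

The source may hold more compounds than are shown below. What is called first, only, known or untested is meant among the compounds shown, and "the series" means these compounds.

Of the compounds shown here, three sharing one core have been measured in an assay for inhibition of serine/threonine-protein kinase 4 (Homo sapiens), read by luminescence and ADP-Glo, in the presence of a further agent that is not named here; on this read-out lower numbers stand for stronger inhibition and higher numbers for weaker inhibition. Compound 1 `OCCCNc1ncnc2[nH]cc(-c3cccc(Cl)c3)c12` gives 94 nM, compound 2 `CCCN(C)c1ncnc2[nH]cc(-c3cccc(Cl)c3)c12` gives 208 nM, and compound 3 `CNC1CCN(c2ncnc3[nH]cc(-c4cccc(Cl)c4)c23)CC1` gives 148 nM. Compound 3 thus sits in the middle of the three, with both neighbours inside the scatter: a 1.6-fold higher number from compound 1 to compound 3 (0.20 log units; within the scatter) and a 1.4-fold lower number from compound 2 to compound 3 (0.15 log units; within the scatter). Compound 4 `Clc1cccc(-c2c[nH]c3ncnc(N4CCCCC4)c23)c1` differs from compound 3 by hydrogen in place of methylamino on a saturated ring carbon. Within the data shown here, no measured step removes a group from this ring; the nearest comparison, a 2.2-fold higher number from compound 1 to compound 2 (0.34 log units; beyond the scatter), swaps one amine side chain for another and shifts the number only modestly. A step of similar size, toward a higher number, is therefore expected: a 1.8-fold higher number from compound 3 to compound 4 (0.24 log units; within the scatter). Compound 4 is estimated at 260 nM, within 110 nM to 650 nM.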

Compound 4, half-maximal inhibitory concentration: 48 nM
Compound 4: the middle estimate sits 5.4-fold (0.73 log units) above what was measured, outside the stated range (below it).
By their numbers in this assay, from the lowest: compounds 4, 1, 3 and 2 (each within the scatter of the next, the first and the last beyond it).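

Taking methylamino off the saturated ring carbon leaves a plain piperidin-1-yl and gives a clear step (a 3.1-fold lower number from compound 3 to compound 4 (0.49 log units; beyond the scatter)), so this amine is not needed for inhibition in this series. The plain ring also improves on the open-chain amine of compound 2 (a 4.3-fold lower number from compound 2 to compound 4 (0.64 log units; beyond the scatter)), while it stays within the scatter of compound 1 (a 2.0-fold lower number from compound 1 to compound 4 (0.29 log units; within the scatter)). No evidence at hand explains these steps.

Still open, from the compounds shown here alone, is whether the step follows from losing the nitrogen of methylamino or the whole group. A hydroxyl or a methyl on that same ring carbon would separate the two.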